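The source may report more compounds than this note shows. Statements on the series, on what has been measured and on what is new or still open speak of the compounds shown alone.

Compound 1 `CCCCc1nc(N2CCN(C(=O)COc3ccc(Cl)cc3)CC2)c2cc(F)sc2n1` gives 1330 nM in a functional assay on cells (Lymphocyte); on this read-out higher numbers stand for weaker inhibition and lower numbers for stronger inhibition.
Compound 2 `Cc1nc(N2CCN(C(=O)COc3ccc(Cl)cc3)CC2)c2cc(F)sc2n1` gives 3390 nM in this assay.
Compound 3 `CCOC(=O)c1nc(N2CCN(C(=O)COc3ccc(Cl)cc3)CC2)c2cc(F)sc2n1` reaches only the limit of > 10000 nM in this assay.

Compound 3 therefore stands at a limit of the assay, a bound and not a number, sitting at the limit of > 10000 nM in this assay, at which 1 of the 3 values shown sits. Among the compounds with values here, the steps that bear on it are an at least 7.5-fold higher number from compound 1 to compound 3 (0.87 log units; beyond the scatter) and an at least 2.9-fold higher number from compound 2 to compound 3 (0.46 log units; beyond the scatter), both bringing the ethoxycarbonyl onto the aromatic carbon. Compound 4 `NC(=O)c1nc(N2CCN(C(=O)COc3ccc(Cl)cc3)CC2)c2cc(F)sc2n1` keeps that carbonyl and differs from compound 3 by amino in place of ethoxy on a carbonyl carbon. Within the data shown here, no measured step alters a group on the carbonyl carbon, so the two ethoxycarbonyl steps are the only guide, and both end beyond the limit. The step is estimated as a number no higher from compound 3 to compound 4 (the limit leaves the size open). Compound 4 is expected near 10000 nM, between 3000 nM and 30000 nM, with a fair chance that only a limit is reported again.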

Compound 4, half-maximal inhibitory concentration: > 10000 nM
Compound 4: a limit, no number; the forecaster's own chance of this, stated with the estimate: 55%; the middle value lies on the limit itself.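

Compound 4, like compound 3, stands at a limit of this assay and gives no number, so two different carbonyl groups on this aromatic carbon now end there: the limit of > 10000 nM in this assay, at which 2 of the 4 values shown sit. Carbamoyl in this place gives an at least 2.9-fold higher number from compound 2 to compound 4 (0.46 log units; beyond the scatter) and an at least 7.5-fold higher number from compound 1 to compound 4 (0.87 log units; beyond the scatter). The step between compound 3 and compound 4 cannot be read, so amino and ethoxy on the carbonyl carbon remain unranked.

Going by these compounds, how far beyond the limit either compound lies remains open. Also open, on these data alone, is whether a carboxylic acid, an amine or a chain longer than butyl on this aromatic carbon would return a readable number.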